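A few compounds are considered here, and "the series" means these few. Any claim that something is new, unique, unknown or untested is made for them only; others in the source may bear on it.

In an ADME assay on HCT-116 cells (Homo sapiens) for cytotoxicity, read by CellTiter-Glo, with a stated time of 72 h (on this read-out lower numbers stand for stronger inhibition and higher numbers for weaker inhibition), three related compounds have been measured so far. Compound 1 `Cc1ccc(-c2ccccc2S(=O)(=O)N2CCC(N3CCC(C)CC3)CC2)cc1` gives > 5000 nM as its reading, which is a limit of the assay and not a number. Compound 2 `CC1CCN(C2CCN(S(=O)(=O)c3ccccc3Br)CC2)CC1` gives > 5000 nM as its reading, again a limit. Compound 3 `CC1CCN(C2CCN(S(=O)(=O)c3ccccc3-c3ccc(Cl)cc3)CC2)CC1` gives > 5000 nM as its reading, also a limit, so it has no exact place on the scale. All that these readings share is the limit of > 5000 nM in this assay, at which 3 of the 3 values shown sit, and nothing finer.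

The next compound is compound 4 `COc1ccc(-c2ccccc2S(=O)(=O)N2CCC(N3CCC(C)CC3)CC2)cc1`. The change methoxy in place of chloro on an aromatic carbon puts methoxy in place of chloro on an aromatic carbon, para to a large group.

The closest measured comparison is a step that the two limits leave unreadable from compound 1 to compound 3 and it also swaps only the small group on that aromatic ring. The other two are a step that the two limits leave unreadable from compound 1 to compound 2 and a step that the two limits leave unreadable from compound 2 to compound 3 and neither gives a size to carry over. With no readable step to build on, no shift beyond the scatter and no clear direction is expected in this assay, and another reported limit is the likeliest outcome.

The expected change is a step that the limit leaves unreadable from compound 3 to compound 4 and this is only an estimate. For compound 4 the estimated value is 8000 nM with an expected range from 4000 nM to 20000 nM in this estimate.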

Compound 4, half-maximal inhibitory concentration: > 5000 nM
Compound 4: only a limit was reported; the forecaster's own chance of this, stated with the estimate: 85%; the middle value lies beyond the limit too.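

In this assay compound 4 gives > 5000 nM, which is a limit and not a number. Its steps from compound 1, compound 2 and compound 3 cannot be read, so no size can be given for any of them: the limit of > 5000 nM in this assay, at which 4 of the 4 values shown sit. The compounds shown leave open where any of them would fall on the scale, and whether methoxy and chloro differ at all.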